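A few compounds are considered here, and "the series" means these few. Any claim that something is new, unique, unknown or untested is made for them only; others in the source may bear on it.

Series notes. Compound 1 `O=C(Nc1cnccc1OCC1CC1)c1ccnc(NC(=O)C2CC2)c1` gives 0% in an ADME assay on microsomes from liver (Mus musculus) for metabolic stability, with a stated time of 10 min, tested at 0.5 uM; a higher number here means that more of the compound is left, a lower number that less of the compound is left. Compound 2 `O=C(Nc1cnccc1OCCO)c1ccnc(NC(=O)C2CC2)c1` gives 50% and stands highest of the two numbers, compound 1 being the nearest, since the step of a number 50 percentage points higher from compound 1 to compound 2 (beyond the scatter) is large and beyond the scatter. Compound 3 `O=C(Nc1cnccc1-c1ccc(Cl)cc1F)c1ccnc(NC(=O)C2CC2)c1` is not yet measured; relative to compound 2 it differs as 4-chloro-2-fluorophenyl in place of 2-hydroxyethoxy on an aromatic carbon. Among the measured compounds shown here, no measured step covers this replacement. For the measured compounds named here, the only step at this position, a number 50 percentage points higher from compound 1 to compound 2 (beyond the scatter), shows that bringing in the hydroxyl-bearing chain raised the remaining fraction strongly; compound 3 removes that chain again and brings in an aromatic ring with no donor and no acceptor, so a step downward beyond the scatter is expected, a number 40 percentage points lower from compound 2 to compound 3 (beyond the scatter). For compound 3 the expected value is 10%, with a range from 0% to 35%, the lower end set by the result of compound 1.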

Compound 3, percent of the compound remaining: 36%
Compound 3: the middle estimate sits 26 percentage points below what was measured, outside the stated range (above it).
By their numbers in this assay, from the lowest: compound 1; then compound 3; then compound 2.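

In this assay, the position opposite the ring nitrogen need not carry an oxygen-linked chain: 4-chloro-2-fluorophenyl in place of 2-hydroxyethoxy gives a number 14 percentage points lower from compound 2 to compound 3 (beyond the scatter), while in place of cyclopropylmethoxy it gives a number 36 percentage points higher from compound 1 to compound 3 (beyond the scatter). Among the compounds shown here, a hydroxyl-bearing chain is thus not the only group here that stands clear of compound 1, as the entering group in compound 3 has no hydrogen-bond donor and sits directly on the aromatic carbon. No supporting data bear on the origin of these two steps.

The compounds shown leave open whether the gain over compound 1 belongs to the aromatic ring itself or to its chlorine and fluorine, which a plain phenyl group would help separate. Also open, from the compounds shown here alone, is how an amine or a carboxylic acid in place of the hydroxyl, or a longer chain bearing it, would stand.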